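Swapping one five-membered ring for another in a kinase-type amide

This account rests on a few compounds, and the source may have more. Where it says the series, first, only, none or still open, it means among the compounds named here.

Of the compounds shown here, two in this set have been tested in a functional assay on PC-3 cells (Homo sapiens) for antiproliferative activity, read by MTT assay, with a stated time of 72 h; on this read-out higher numbers stand for weaker inhibition and lower numbers for stronger inhibition. Compound 1 `COc1cc2c(Oc3ccc(NC(=O)C4(c5nnc(-c6ccc(F)cc6)o5)CC4)cc3F)ccnc2cc1OCCCN1CCCC1` gives 2340 nM. Compound 2 `COc1cc2c(Oc3ccc(NC(=O)c4cc(-c5ccc(F)cc5)on4)cc3)ccnc2cc1OCCCN1CCC(C)CC1` gives 2040 nM. Compound 2 has the lowest number of the two, but its gap to compound 1 is within the scatter, so the two cannot be ranked against each other.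

Compound 3 `COc1cc2c(Oc3ccc(NC(=O)c4nc(-c5ccc(F)cc5)no4)cc3)ccnc2cc1OCCCN1CCC(C)CC1` is not yet measured. It differs from compound 2 in one place: 3-(4-fluorophenyl)-1,2,4-oxadiazol-5-yl in place of 5-(4-fluorophenyl)-1,2-oxazol-3-yl on a carbonyl carbon. Among the measured compounds shown here, no measured pair in this set shows how such a ring swap plays out, so nothing beyond the structural change itself can guide the expectation.

With that in mind, the step from compound 2 to compound 3 is expected to be small, a 1.2-fold higher number from compound 2 to compound 3 (0.09 log units; within the scatter), not beyond the scatter in either direction. Compound 3 is therefore estimated at 2500 nM in this assay, within a range of 900 nM to 7000 nM.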

Compound 3, half-maximal inhibitory concentration: 1040 nM
Estimate against measurement, compound 3: 2.4-fold (0.38 log units) above; the measured number falls inside the stated range.
By their numbers in this assay, from the lowest: compounds 3, 2 and 1 (each within the scatter of the next, the first and the last beyond it).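

Among the compounds shown here, this is the first measured pair in the set that differs only in the five-membered ring on the carbonyl carbon, with the amide-type nitrogen and the rest of the molecule unchanged. In this assay the swap gives a 2.0-fold lower number from compound 2 to compound 3 (0.29 log units; within the scatter), so compound 2 and compound 3 cannot be ranked, and this position accepts 3-(4-fluorophenyl)-1,2,4-oxadiazol-5-yl as well as 5-(4-fluorophenyl)-1,2-oxazol-3-yl without a clear change in the read-out. No supporting measurement bears on why the two rings give such similar numbers.

This single pair leaves open how a thiazole or a 1,2,3-triazole ring would fare at the same place. It also leaves open whether the same result would hold if the 4-fluorophenyl group on the ring were replaced by a pyridine ring or a carboxylic acid.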